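Replacing Fluorophenyl with Chlorophenyl: Expected Vero Cell Tolerance

This account rests on a few compounds, and the source may have more. Where it says the series, first, only, none or still open, it means among the compounds named here.

Compound 3 `COc1nc(-c2cccc(F)c2)ccc1[C@@H](c1ccccc1)[C@@](O)(CCN(C)C)c1cccc2ccccc12` was tested in a toxicity assay on Vero cells (Chlorocebus sabaeus) for cytotoxicity; a higher number here means that more compound is tolerated, a lower number that less compound is tolerated. Compound 3 reaches only the limit > 50 ug/mL there, not a number. Compound 2 `COc1ccc(-c2ccc([C@@H](c3ccccc3)[C@@](O)(CCN(C)C)c3cccc4ccccc34)c(OC)n2)cc1` likewise stops at the limit > 50 ug/mL. Compound 1 `COc1nc(-c2ccsc2)ccc1[C@@H](c1ccccc1)[C@@](O)(CCN(C)C)c1cccc2ccccc12`, which carries thiophen-3-yl, gives 24.4 ug/mL. Two steps are readable: an at least 2.0-fold higher number from compound 1 to compound 2 (0.31 log units; beyond the scatter) and an at least 2.0-fold higher number from compound 1 to compound 3 (0.31 log units; beyond the scatter). The step that the two limits leave unreadable from compound 2 to compound 3 cannot be sized because of the limit of > 50 ug/mL in this assay, at which 2 of the 3 values shown sit. Compound 4 `COc1nc(-c2ccc(Cl)cc2)ccc1[C@@H](c1ccccc1)[C@@](O)(CCN(C)C)c1cccc2ccccc12` differs from compound 3 in one place: 4-chlorophenyl in place of 3-fluorophenyl on an aromatic carbon. Going by the values given here, no measured step swaps one phenyl substituent for another with a readable size, so the expectation rests on compound 3 sitting at the limit. Compound 4 is therefore expected near 50 ug/mL, between 25 ug/mL and 100 ug/mL, which means an expected step of a number no higher from compound 3 to compound 4 (the limit leaves the size open).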

Compound 4, half-maximal cytotoxic concentration: > 50 ug/mL
Compound 4: only a limit was reported; the forecaster's own chance of this, stated with the estimate: 60%; the middle value sits exactly at the limit.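

With 4-chlorophenyl on this aromatic carbon, compound 4 also stops at a limit in this assay, so three differently substituted phenyl groups now share that limit, and only the thiophen-3-yl of compound 1 gives a number. Against that thiophen-3-yl, 4-chlorophenyl gives an at least 2.0-fold higher number from compound 1 to compound 4 (0.31 log units; beyond the scatter). The steps from compound 2 and compound 3 to compound 4 cannot be read because all three compounds stop at the same limit: the limit of > 50 ug/mL in this assay, at which 3 of the 4 values shown sit.

Going by these compounds, how far apart these three compounds really lie stays open. Also open, on these data alone, is whether a phenyl group carrying an amine or a carboxylic acid here would stay at this limit.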